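Shortening the Side Chain from Ethyl to Methyl

A few compounds are considered here, and "the series" means these few. Any claim that something is new, unique, unknown or untested is made for them only; others in the source may bear on it.

Of the compounds shown here, two share a common core and have been tested in a functional assay on the whole organism with Mus musculus as the target; a lower number here means a smaller maximal response, a higher number a larger maximal response. Compound 1 `CCOC(=O)Cn1c(=O)n(C2OC(CO)[C@@H](O)[C@H]2O)c2nc(N)nc(O)c21` carries an ethoxycarbonyl group on a saturated chain carbon bound to an aromatic nitrogen, and in this assay compound 1 gives 58%. Compound 2 `CCn1c(=O)n(C2OC(CO)[C@@H](O)[C@H]2O)c2nc(N)nc(O)c21` has a methyl at that place instead; in this assay compound 2 gives 82%, the higher of the two numbers. Among the measured compounds shown here, the only measured step so far is a number 24 percentage points higher from compound 1 to compound 2 (beyond the scatter).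

Compound 3 `Cn1c(=O)n(C2OC(CO)[C@@H](O)[C@H]2O)c2nc(N)nc(O)c21` has not yet been measured. Its change from compound 2 is hydrogen in place of methyl on a saturated chain carbon bound to an aromatic nitrogen. For the measured compounds named here, the step from compound 1 to compound 2 concerns the same place and is the only available guide, but it exchanges a different group, so it says little about shortening ethyl to methyl. A step close to the scatter therefore seems most likely, with some chance of a modest fall. Compound 3 is expected to give about 78% in this assay, within 60% to 95%. That estimate corresponds to a number 4 percentage points lower from compound 2 to compound 3 (within the scatter), a change expected to stay within the scatter.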

Compound 3, largest response reached (reported as maximal response), in percent of the reference or control that the assay uses: 100%
Compound 3: the middle estimate sits 22 percentage points below what was measured, and the stated range ends below it.
By their numbers in this assay, from the lowest: compound 1; then compound 2; then compound 3.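

In this assay, shortening ethyl to methyl on the aromatic nitrogen is not a silent change: it gives a number 18 percentage points higher from compound 2 to compound 3 (beyond the scatter), so even the loss of a single carbon at this place registers in the maximal response. Taken together, the three compounds form one order, with the response rising as the group on the saturated chain carbon goes from ethoxycarbonyl to methyl to hydrogen; the full span is a number 42 percentage points higher from compound 1 to compound 3 (beyond the scatter), and none of the three goes against this order. No accompanying measurement bears on the reason for this rise.

With only three groups compared at this place, the order is a description of these compounds and not yet a rule that could be applied to others. As far as these compounds go, it remains open how a longer chain such as propyl, or a carboxylic acid or an amine on the saturated chain carbon, would fit into this order, and whether the response would keep following the length of the chain or depend on the kind of group attached.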